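Bromo in place of 2-methylphenyl on the shared core

The source may report more compounds than this note shows. Statements on the series, on what has been measured and on what is new or still open speak of the compounds shown alone.

Compound 1 `CCOc1ccccc1-c1ccc(-c2nc3cnccc3c(N[C@H](CC)C(N)=O)c2C#N)cc1` and compound 2 `CC[C@@H](Nc1c(C#N)c(-c2ccc(-c3ccccc3C)cc2)nc2cnccc12)C(N)=O` have both been read in a physicochemical assay for lipophilicity, read by HPLC, at pH 7.5; a lower number here means a more polar compound, a higher number a more lipophilic compound. Going by the values given here, there compound 1 gives 3 and compound 2 gives 3, so compound 2 stands level with its only measured neighbour. Compound 3 `CC[C@@H](Nc1c(C#N)c(-c2ccc(Br)cc2)nc2cnccc12)C(N)=O` keeps the rest of compound 2 but carries bromo in place of 2-methylphenyl on an aromatic carbon, para to a large group: bromo in place of 2-methylphenyl on an aromatic carbon. Among the compounds with values here, only one measured step bears on this change. The step of no change at the digits printed from compound 1 to compound 2 (within the scatter) is methyl in place of ethoxy on an aromatic carbon, and it stayed within the scatter. In that step the aromatic ring remained and only a group on it was exchanged, whereas here the whole ring leaves. Within the data shown here, it therefore sets no direct size for this change, and no measured pair shows such a ring being removed. With 2-methylphenyl gone, a downward step of a number 0.70 log units lower from compound 2 to compound 3 (beyond the scatter) is expected, beyond the scatter, though this estimate carries wide margins. Compound 3 is estimated at 2.3, with a range from 1.7 to 2.9.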

Compound 3, distribution coefficient: 2.2
The estimate for compound 3 lay 0.10 log units above the measured number; the measured number falls inside the stated range.
By their numbers in this assay, from the lowest: compound 3; then compounds 1 and 2 (each within the scatter of the next).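

In this assay, going by these compounds alone, the earlier pair showed only that exchanging a group on the outer ring, with that ring kept, left the read-out within the scatter. Compound 3 shows that the position on an aromatic carbon, para to a large group, does respond once the whole ring leaves: bromo in place of 2-methylphenyl gives a number 0.80 log units lower from compound 2 to compound 3 (beyond the scatter) and so moves the number beyond the scatter. Bromo in place of 2-ethoxyphenyl gives a number 0.80 log units lower from compound 1 to compound 3 (beyond the scatter) as well, so the step is the same size from either of the two level ring-bearing compounds, and no measurement shown explains that shift or separates the loss of the ring from the arrival of bromo.

The compounds shown therefore leave open how much of the step belongs to the loss of the ring and how much to the arrival of bromo, and a plain hydrogen or a chloro group at this position would bear on that question. Within the data shown here, they also leave open how the number would respond to an amine, a carboxylic acid or a pyridine ring there, since only one ring of carbon and one halogen appear at this place.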